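The source may hold more compounds than are shown below. What is called first, only, known or untested is meant among the compounds shown, and "the series" means these compounds.

Three compounds share one core. Compound 1 `COc1ccc(NC(=O)Nc2cc(C)nc3ccccc23)cc1F` sits at a limit in an ADME assay on Raji cells (Homo sapiens) for cytotoxicity, with a stated time of 72 h (a lower number here means that less compound is needed, a higher number that more compound is needed for the effect), and gives > 25000 nM. Compound 3 `Cc1cc(NC(=O)Nc2ccc(F)c(F)c2)c2ccccc2n1` likewise sits at a limit and gives > 25000 nM in this assay. The step from compound 1 to compound 3, a step that the two limits leave unreadable from compound 1 to compound 3, cannot be read, since (the limit of > 25000 nM in this assay, at which 3 of the 3 values shown sit). Compound 2 `Cc1cc(NC(=O)Nc2cccc(C(N)=O)c2)c2ccccc2n1` stands at the same place: in this assay compound 2 gives > 25000 nM, which is a limit. Compound 4 `COc1cccc(NC(=O)Nc2cc(C)nc3ccccc23)c1` differs from compound 2 by methoxy in place of carbamoyl on an aromatic carbon. Among the measured compounds shown here, no measured step covers this change, and the only measured step says nothing beyond its limits. The chemist therefore expects compound 4 to remain at the limit, with an estimated step that the limit leaves unreadable from compound 2 to compound 4. The estimate for compound 4 in this assay is 30000 nM, between 8000 nM and 100000 nM.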

Compound 4, half-maximal effective concentration: > 25000 nM
Compound 4 was reported as a limit; the forecaster's own chance of this, stated with the estimate: 85%; the middle value lies beyond the limit too.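

No new step can be read between compound 2 and compound 4, since both values are limits: the limit of > 25000 nM in this assay, at which 4 of the 4 values shown sit.

The compounds shown leave open how these four compounds truly differ in this assay, and whether any change on the shared core gives a readable value.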